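From chloro to nitro on one aromatic carbon

The source may report more compounds than this note shows. Statements on the series, on what has been measured and on what is new or still open speak of the compounds shown alone.

In an ADME assay on cells (Erythrocyte, Homo sapiens), read by hemolysis, with a stated time of 1 h (on this read-out lower numbers stand for stronger inhibition and higher numbers for weaker inhibition), compound 3 (`CC(=NNC(=S)Nc1ccc(Cl)cc1)c1ccccn1`) gives > 10000 nM as a limit and not a number. Compound 1 (`CC(=NNC(=S)Nc1cccc(F)c1)c1ccccn1`) gives > 10000 nM as a limit too. Compound 2 (`CC(=NNC(=S)Nc1ccc(I)cc1)c1ccccn1`) also gives > 10000 nM as a limit. All the data therefore sit at the limit of > 10000 nM in this assay, at which 3 of the 3 values shown sit, and nothing more. Among the measured compounds shown here, the only measured step is a step that the two limits leave unreadable from compound 2 to compound 3 and it is the sole guide here. Compound 4 (`CC(=NNC(=S)Nc1ccc([N+](=O)[O-])cc1)c1ccccn1`) carries nitro in place of chloro on an aromatic carbon, para to a large group: nitro in place of chloro on an aromatic carbon in all. No shift beyond the scatter, in either direction, is expected in this assay for this change. The expected step is a step that the limit leaves unreadable from compound 3 to compound 4 as estimated. Compound 4 is estimated at 15000 nM with an expected range from 7000 nM to 40000 nM and will probably remain a limit.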

Compound 4, half-maximal inhibitory concentration: > 10000 nM
Compound 4: no number, only a limit; the forecaster's own chance of this, stated with the estimate: 85%; the middle value lies beyond the limit too.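

The values of compound 2, compound 3 and compound 4 are limits and not numbers, and no step among these compounds can be read in this assay: the limit of > 10000 nM in this assay, at which 4 of the 4 values shown sit.

The compounds shown leave open whether iodo, chloro and nitro differ at all on this read-out.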